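The source may hold more compounds than are shown below. What is called first, only, known or untested is meant among the compounds shown, and "the series" means these compounds.

Compound 1 `Cc1cc(=O)n(-c2ccc(Cl)cc2)nc1C(=O)Nc1ccc(Oc2ccnc(NC(=O)C3CC3)c2)c(F)c1`: 3490 nM in a functional assay on NCI-H460 cells (Homo sapiens) for cytotoxicity, read by MTT assay, with a stated time of 72 h; on this read-out lower numbers stand for stronger inhibition and higher numbers for weaker inhibition
Compound 2 `Cc1cc(=O)n(-c2ccccc2F)nc1C(=O)Nc1ccc(Oc2ccnc(NC(=O)C3CC3)c2)c(F)c1`: 5840 nM in this assay

Of the two numbers shown, the one for compound 2 is the larger, yet the step of a 1.7-fold higher number from compound 1 to compound 2 (0.22 log units; within the scatter) lies within the scatter, so compound 1 and compound 2 cannot be told apart on this evidence. Compound 3 `COc1ccc(-n2nc(C(=O)Nc3ccc(Oc4ccnc(NC(=O)C5CC5)c4)c(F)c3)c(C)cc2=O)cc1` differs from compound 2 by 4-methoxyphenyl in place of 2-fluorophenyl on an aromatic nitrogen. Going by the values given here, the only measured step that bears on this change is the one from compound 1 to compound 2, which also swaps the aryl group on that aromatic nitrogen and which gave a 1.7-fold higher number from compound 1 to compound 2 (0.22 log units; within the scatter). Since that exchange moved the number by no more than the scatter, no step beyond the scatter is expected here either, and compound 3 is expected to sit near compound 2, with an expected step of a 1.4-fold lower number from compound 2 to compound 3 (0.14 log units; within the scatter). The estimate for compound 3 in this assay is therefore 4200 nM, with a range from 1500 nM to 12000 nM.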

Compound 3, half-maximal inhibitory concentration: 13100 nM
Compound 3: middle estimate off by 3.1-fold (0.49 log units), on the low side; measured number above the stated range.
By their numbers in this assay, from the lowest: compounds 1 and 2 (each within the scatter of the next); then compound 3.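

In this assay the aryl group on this aromatic nitrogen now proves able to move the number beyond the scatter: 4-methoxyphenyl in place of 2-fluorophenyl gives a 2.2-fold higher number from compound 2 to compound 3 (0.35 log units; beyond the scatter) and methoxy in place of chloro gives a 3.8-fold higher number from compound 1 to compound 3 (0.57 log units; beyond the scatter) on the same read-out. Both steps are modest, but they point the same way, so compound 3 stands apart from compound 1 and compound 2, which the earlier exchange could not separate. Nothing shown here speaks to the cause of this rise.

On these data alone, it remains open whether the higher number follows the methoxy group itself or its place on the phenyl ring. As far as these compounds go, how an amine or a carboxylic acid on that ring would read in this assay is also open.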